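Ester to azetidine amide on a protected nucleoside scaffold

This account rests on a few compounds, and the source may have more. Where it says the series, first, only, none or still open, it means among the compounds named here.

The measured compounds are:
compound 1 `COC(=O)C(=O)CNC1=CS(=O)(=O)O[C@@]12[C@@H](CO[Si](C)(C)C(C)(C)C)O[C@@H](n1cc(C)c(=O)n(C)c1=O)[C@@H]2O[Si](C)(C)C(C)(C)C`, 5570 nM;
compound 2 `Cc1cn([C@@H]2O[C@@H]3COC(=O)[C@]3(OS(C)(=O)=O)[C@H]2O)c(=O)[nH]c1=O`, 160000 nM;
compound 3 `Cc1cn([C@@H]2O[C@@H]3COC4(O)CS(=O)(=O)O[C@@]34[C@H]2O)c(=O)[nH]c1=O`, 100000 nM.

In a functional assay on CCRF-CEM cells (Homo sapiens) (on this read-out higher numbers stand for lower toxicity in this test and lower numbers for higher toxicity in this test), compound 1 gives 5570 nM, the lowest of the three numbers. Compound 3 gives 100000 nM and compound 2 gives 160000 nM, both well beyond the usual scatter away from compound 1, so compound 1 is the most toxic of the three in this assay. For the measured compounds named here, compounds 2 and 3 differ from compound 1 in several places at once, so no single step between measured compounds can be read from them.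

Compound 4 `Cc1cn([C@@H]2O[C@H](CO[Si](C)(C)C(C)(C)C)[C@@]3(OS(=O)(=O)C=C3NCC(=O)C(=O)N3CCC3)[C@H]2O[Si](C)(C)C(C)(C)C)c(=O)n(C)c1=O` has not yet been measured. It differs from compound 1 in one place: azetidin-1-yl in place of methoxy on a carbonyl carbon. Going by the values given here, nothing among the measured compounds shows what a change of this kind does in this assay, so no direction is supported by the data. The step from compound 1 to compound 4 is therefore expected to be small, a 1.1-fold higher number from compound 1 to compound 4 (0.03 log units; within the scatter), within or close to the scatter. For compound 4 the estimate in this assay is 6000 nM, with a range from 1500 nM to 25000 nM.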

Compound 4, half-maximal cytotoxic concentration: 21600 nM
For compound 4 the middle estimate is 3.6-fold (0.56 log units) below the measured one; low and high end bracket the measured number.
By their numbers in this assay, from the lowest: compound 1; then compound 4; then compounds 3 and 2 (each within the scatter of the next).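

In this assay, for the compounds shown here, the change to azetidin-1-yl in place of methoxy on a carbonyl carbon gives a 3.9-fold higher number from compound 1 to compound 4 (0.59 log units; beyond the scatter) and is the first single change that can be read in this set. It shows that this position is not silent. Compound 4 differs from compound 1 in this one group only, and its number is higher by a modest step beyond the scatter, towards lower toxicity in this test. No measurement shown bears on the reason for this step.

The compounds shown leave open whether the step is particular to azetidin-1-yl or would also follow from another replacement of methoxy, such as dimethylamino, pyrrolidin-1-yl or a free carboxylic acid on the same carbonyl carbon. They also leave open whether it would hold with hydrogen in place of the tert-butyldimethylsilyl groups.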